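Swapping the aryl sulfone partner in a weak potassium channel blocker

The compounds below may be only part of what the source reports. "The series", "measured", "known", "first", "only" and "open" are said of these compounds alone.

Measured so far:
compound 1 `CC(O)(C(=O)Nc1ccc(S(=O)(=O)c2cccc(O)c2)cc1)C(F)(F)F`: 18000 nM
compound 2 `CC(O)(C(=O)Nc1ccc(S(=O)(=O)c2ccccc2)c([N+](=O)[O-])c1)C(F)(F)F`: > 30000 nM

Among the compounds with values here, compound 1 is the only compound with a full number in a functional assay (Cavia porcellus) with sulfonylurea receptors; K-ATP channels (Homo sapiens) as the target; on this read-out lower numbers stand for stronger inhibition and higher numbers for weaker inhibition. Compound 2 gives > 30000 nM in this assay, and that is a limit of the assay rather than a number (the limit of > 30000 nM in this assay, at which 1 of the 2 values shown sits). Compound 1 therefore stands as a weak inhibitor, with no second measured number to compare it to.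

Compound 3 `CC(O)(C(=O)Nc1ccc(S(=O)(=O)c2ccccn2)cc1)C(F)(F)F` differs from compound 1 in one place: pyridin-2-yl in place of 3-hydroxyphenyl on a sulfonyl sulfur. Within the data shown here, no measured pair shows what such a swap does in this assay. The step from compound 1 to compound 3 is therefore expected to be no larger than the scatter, a 1.4-fold higher number from compound 1 to compound 3 (0.14 log units; within the scatter), with some chance that only a limit is returned. Compound 3 is estimated at 25000 nM, in a range from 8000 nM to 80000 nM.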

Compound 3, half-maximal inhibitory concentration: 600 nM
Compound 3: the middle estimate sits 42-fold (1.62 log units) above what was measured; measured number outside the range, below it.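

Pyridin-2-yl in place of 3-hydroxyphenyl on a sulfonyl sulfur gives a 30-fold lower number from compound 1 to compound 3 (1.48 log units; beyond the scatter) in this assay and so shows that this place can strongly change the read-out. The earlier compounds shown here could not show this, as they offered one full number and one limit, with no step between them. Nothing shown explains why this swap has so large an effect.

The swap removes a hydroxyl group and brings in a ring nitrogen at the same time, so the compounds shown do not separate the share of each change in the step. Also open, from the compounds shown here alone, is whether the gain is particular to pyridin-2-yl or would carry over to a related ring such as pyridin-4-yl on the same core.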